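From propanoylamino to nitro on the shared core

The source may hold more compounds than are shown below. What is called first, only, known or untested is meant among the compounds shown, and "the series" means these compounds.

Within the data shown here, in a toxicity assay on Huh-7.5 cells (Homo sapiens) for inhibition, read by MTT assay, with a stated time of 96 h (a higher number here means that more compound is tolerated, a lower number that less compound is tolerated), compound 3 (`CCC(=O)Nc1cc(C(=O)Nc2ccc(OC)cc2)ccc1OC(C)C`) gives 113000 nM, the highest of the three numbers measured so far. Compound 4 (`COc1ccc(NC(=O)c2ccc(OC(C)C)c([N+](=O)[O-])c2)cc1`) carries nitro in place of propanoylamino on an aromatic carbon, ortho to an isopropoxy group: nitro in place of propanoylamino on an aromatic carbon. Among the measured compounds shown here, no measured pair isolates this change. However, two other compounds carrying a nitro group stand lower than compound 3 by more than the scatter: compound 1 (`COc1ccc(NC(=O)c2ccc(OCCCCl)c([N+](=O)[O-])c2)cc1`) at 39700 nM and compound 2 (`CC(C)Oc1ccc(C(=O)Nc2ccc(N(C)C)cc2)cc1[N+](=O)[O-]`) at 50000 nM. A step to a lower number in this assay, beyond the scatter, is therefore expected. The expected change is a 2.5-fold lower number from compound 3 to compound 4 (0.40 log units; beyond the scatter). For compound 4, the estimated half-maximal cytotoxic concentration is 45000 nM, with an expected range of 20000 nM to 100000 nM.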

Compound 4, half-maximal cytotoxic concentration: 23400 nM
Estimate against measurement, compound 4: 1.9-fold (0.28 log units) above; the range from low to high includes it.
By their numbers in this assay, from the lowest: compounds 4, 1 and 2 (each within the scatter of the next, the first and the last beyond it); then compound 3.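

In this assay, the change ortho to an isopropoxy group can now be read directly: nitro in place of propanoylamino on an aromatic carbon gives a 4.8-fold lower number from compound 3 to compound 4 (0.68 log units; beyond the scatter). With the nitro group kept, methoxy in place of dimethylamino on an aromatic carbon gives a 2.1-fold lower number from compound 2 to compound 4 (0.33 log units; beyond the scatter). Isopropyl in place of 3-chloropropyl on an oxygen on an aromatic ring gives a 1.7-fold lower number from compound 1 to compound 4 (0.23 log units; within the scatter), so that change does not separate the two compounds.

On these data alone, how an amine or a carboxylic acid at the same position would compare remains open. The compounds shown offer no explanation for the step from propanoylamino to nitro.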